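The compounds below may be only part of what the source reports. "The series", "measured", "known", "first", "only" and "open" are said of these compounds alone.

Compound 1 `Oc1cccc(-c2cc(-c3ccccc3)cc(-c3ccco3)n2)c1`: 9910 nM
Compound 2 `Oc1ccc(-c2cc(-c3ccccc3)cc(-c3ccccc3)n2)cc1`: 1400 nM
Compound 3 `Oc1cccc(-c2cc(-c3ccccc3)nc(-c3ccccc3)c2)c1`: 13500 nM

All three values come from a functional assay on HL-60 cells (Homo sapiens) for cytotoxicity, read by ELISA, with a stated time of 2 days; a lower number here means a stronger inhibitor, a higher number a weaker inhibitor. Compound 3 gives 13500 nM, and compound 1 gives 9910 nM. These two values lie within the scatter of each other, so they cannot be told apart. Compound 2, at 1400 nM, has a lower number than compound 3 by a margin beyond the scatter, making it the stronger inhibitor of that pair.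

The next compound is compound 4 `Oc1cccc(-c2cc(-c3ccccc3)nc(-c3ccsc3)c2)c1`. It carries thiophen-3-yl in place of phenyl on an aromatic carbon next to the ring nitrogen: thiophen-3-yl in place of phenyl on an aromatic carbon. For the measured compounds named here, no two measured compounds differ in one place only, so the data do not show the effect of this swap directly. With nothing to suggest a large shift, no change beyond the scatter is expected in this assay, though a small drop in the number is possible. The estimated change is a 1.5-fold lower number from compound 3 to compound 4 (0.18 log units; within the scatter). For compound 4 the estimated value is 9000 nM, with an expected range of 3500 nM to 24000 nM.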

Compound 4, half-maximal inhibitory concentration: 12000 nM
Compound 4: middle estimate off by 1.3-fold (0.12 log units), on the low side; the measured number falls inside the stated range.
By their numbers in this assay, from the lowest: compound 2; then compounds 1, 4 and 3 (each within the scatter of the next).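

In this assay, putting thiophen-3-yl in place of phenyl on an aromatic carbon next to the ring nitrogen gives a 1.1-fold lower number from compound 3 to compound 4 (0.05 log units; within the scatter), so the two compounds cannot be told apart. For the compounds shown here, this pair is the first direct comparison at this position, and it shows that a five-membered aromatic ring with one sulfur and a six-membered aromatic ring of carbon only give values within the scatter of each other here. No measurement shown explains this match. 

As far as these compounds go, whether a group of a different kind at this position, such as an amine or a carboxylic acid, would give a clearly different number remains open. Also open, from the compounds shown here alone, is whether the same ring swap would give a similar result at the other phenyl group on the shared core.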